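Benzimidazole replaced by a trimethylpyrazole on the shared core

This account rests on a few compounds, and the source may have more. Where it says the series, first, only, none or still open, it means among the compounds named here.

Compound 3 `Cc1cc(C)c(-c2nc3ccccc3[nH]2)cc1NC(=O)c1ccc(OCc2ccccn2)cc1` carries a benzimidazole on the shared core. In a physicochemical assay for lipophilicity (on this read-out lower numbers stand for lower lipophilicity and higher numbers for higher lipophilicity), compound 3 reaches only a limit, > 3.5, so no number is known for it. Compound 2 `Cc1cc(C)c(-c2cn(C)cn2)cc1NC(=O)c1ccc(OCc2ccccn2)cc1` gives 3 in this assay, and compound 1 `Cc1cc(Cl)c(-c2cn(C)c(C)n2)cc1NC(=O)c1ccc(OCc2ccccn2)cc1` gives 3.3. Going by the values given here, the one measured step that touches the benzimidazole is a number at least 0.50 log units higher from compound 2 to compound 3 (beyond the scatter); its full size stays open due to the limit of > 3.5 in this assay, at which 1 of the 3 values shown sits. Compound 4 `Cc1cc(C)c(-c2c(C)nn(C)c2C)cc1NC(=O)c1ccc(OCc2ccccn2)cc1` is not yet measured in this assay. The change from compound 3 is 1,3,5-trimethyl-1H-pyrazol-4-yl in place of 1H-benzimidazol-2-yl on an aromatic carbon. Among the compounds with values here, no measured step pairs these two groups directly; what is known is that compound 2 and compound 1, each with a methylated five-membered azole in the same position, both give numbers inside the range of this assay. Compound 4 is therefore expected to return to a measurable number, with the step of a number at least 0.20 log units lower from compound 3 to compound 4 (that floor lies within the scatter) expected to run downward beyond the scatter. The estimate for compound 4 in this assay is 3.3, with a range from 2.9 to 3.7.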

Compound 4, distribution coefficient: > 3
Compound 4 was reported as a limit (the forecaster's own chance of this, stated with the estimate: 15%); the middle value is on the limit's open side.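

In this assay compound 4 gives > 3, which is a limit and not a number. The only direction available is a number no lower from compound 2 to compound 4 (the limit leaves the size open); the size of that step and the step from compound 3 to compound 4 cannot be read. A limit at this position is therefore not confined to 1H-benzimidazol-2-yl with its 1 hydrogen-bond donor, since 1,3,5-trimethyl-1H-pyrazol-4-yl, with 0 hydrogen-bond donors, also gives one.

From the compounds shown here alone, the actual number for compound 4 in this assay stays open, as does any order between compound 3 and compound 4. Also open, going by these compounds, is whether a group carrying an amine or a carboxylic acid, in place of 1,3,5-trimethyl-1H-pyrazol-4-yl on the shared core, would give a number rather than a limit in this assay.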